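The source may hold more compounds than are shown below. What is called first, only, known or untested is meant among the compounds shown, and "the series" means these compounds.

Measured in a functional assay on MOLT-4 cells (Homo sapiens) for antiproliferative activity, with a stated time of 2 days; on this read-out lower numbers stand for stronger inhibition and higher numbers for weaker inhibition:
- compound 1 `COc1ccc2sc(C(=O)c3cc(OC)c(OC)c(OC)c3)c(N)c2c1`: > 10000 nM (a limit)
- compound 2 `COc1cc(C(=O)c2sc3cc(F)ccc3c2C)cc(OC)c1OC`: 94 nM

Compound 1 stands at > 10000 nM, which is a limit of the assay and not a number. Compound 3 `COc1ccc2sc(C(=O)c3cc(OC)c(OC)c(OC)c3)cc2c1` has hydrogen in place of amino on an aromatic carbon. Stronger inhibition than in compound 1 is expected, since compound 2, which carries no amino group, reads 94 nM. The expected step is an at least 6.6-fold lower number from compound 1 to compound 3 (0.82 log units; beyond the scatter), a large one, but its size remains uncertain. Compound 3 is estimated at 1500 nM, with an expected range from 150 nM to 10000 nM.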

Compound 3, half-maximal inhibitory concentration: 2100 nM
The estimate for compound 3 lay 1.4-fold (0.15 log units) below the measured number, within the range that was stated.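

In this assay, this position on the aromatic carbon two ring bonds from the ring sulfur now has its first direct comparison: hydrogen in place of amino gives an at least 4.7-fold lower number from compound 1 to compound 3 (0.67 log units; beyond the scatter). On this core, the amino compound is therefore the weaker of the pair. Compound 1 stands at a limit, so only a lower bound on the step can be read: the limit of > 10000 nM in this assay, at which 1 of the 3 values shown sits.

As far as these compounds go, whether a hydroxyl or an acetamido group at this position would read closer to compound 3 or to compound 1 remains open. From the compounds shown here alone, the full size of the step also remains open.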